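Ether substituent change on compound 3: working notes

The compounds below may be only part of what the source reports. "The series", "measured", "known", "first", "only" and "open" are said of these compounds alone.

Compound 1 `C#CCCCOc1ccc2cc(C(=O)OC)c(=O)oc2c1` gives 953 nM in an assay on cells for inhibition of Amine oxidase [flavin-containing] A (Homo sapiens), read by Amplex Red, with stated times of 30 min and 45 min; on this read-out higher numbers stand for weaker inhibition and lower numbers for stronger inhibition. Compound 2 `C#CCCCOc1ccc2cc(C(=O)O)c(=O)oc2c1` gives only a limit in this assay, namely > 10000 nM. Compound 3 `C#CCCCOc1ccc2cc(NC(C)=O)c(=O)oc2c1` gives 930 nM in this assay, the lower of the two numbers shown, though the gap to compound 1, a 1.0-fold lower number from compound 1 to compound 3 (0.01 log units; within the scatter), is within the scatter and sets no order between them. The step of an at least 10-fold higher number from compound 1 to compound 2 (1.02 log units; beyond the scatter) is large, and an at least 10-fold lower number from compound 2 to compound 3 (1.03 log units; beyond the scatter) is its counterpart; both rest on the limit described as the limit of > 10000 nM in this assay, at which 1 of the 3 values shown sits. Every measured step changes the group on the aromatic carbon of the shared core and leaves the ether chain untouched.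

Compound 4 `CC(=O)Nc1cc2ccc(OCc3cccc(Cl)c3)cc2oc1=O` differs from compound 3 at that chain instead: 3-chlorophenyl in place of but-3-yn-1-yl on a saturated chain carbon bound to an oxygen on an aromatic ring. For the measured compounds named here, no measured step bears on this position, so the measured steps give neither a direction nor a size for it. The expected step from compound 3 to compound 4 in this assay is therefore a 1.0-fold lower number from compound 3 to compound 4 (0.01 log units; within the scatter), none beyond the scatter, with a correspondingly wide range. Compound 4 is estimated at 900 nM, between 150 nM and 6000 nM.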

Compound 4, half-maximal inhibitory concentration: 62.7 nM
Beside the measured number, compound 4's estimate is 14-fold (1.16 log units) above it; the measured number lies below the stated range.
By their numbers in this assay, from the lowest: compound 4; then compounds 3 and 1 (each within the scatter of the next). At a limit, above all of these: compound 2.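

The ether chain, left untouched by every earlier step, now proves able to move the number in this assay: a 15-fold lower number from compound 3 to compound 4 (1.17 log units; beyond the scatter) is a large step, and it comes from this position alone, with the acetamido group held constant. The exchange of pent-4-yn-1-yl for 3-chlorobenzyl removes the triple bond and brings in an aromatic ring and a chlorine at once, so this single step cannot divide its size among those parts. Nothing measured here gives a cause for the step.

Open, going by these compounds, is whether the chlorine contributes at all, which an unsubstituted benzyl ether would address. Also open, on these data alone, is whether the 3-chlorobenzyl ether gives a step of similar size with methoxycarbonyl or a carboxylic acid in place of the acetamido group.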